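Ring swap on the amide of compound 1

This account rests on a few compounds, and the source may have more. Where it says the series, first, only, none or still open, it means among the compounds named here.

Compound 1 `CC1CCN(C(=O)CN(C)C(=O)c2ccc(S(C)(=O)=O)c([N+](=O)[O-])c2)CC1` is one of three amides on the shared core for which only limits are known. In an assay on isolated protein for inhibition of vitamin D3 receptor (Homo sapiens), read by fluorescence polarization (on this read-out higher numbers stand for weaker inhibition and lower numbers for stronger inhibition), compound 1 gives > 60000 nM, a limit of the assay rather than a number. Compound 2 `CS(=O)(=O)c1ccc(C(=O)NCCCC(=O)N2Cc3ccccc3C2)cc1[N+](=O)[O-]` in this assay gives > 60000 nM, again a limit. Compound 3 `CC(C)N(C(=O)CCNC(=O)c1ccc(S(C)(=O)=O)c([N+](=O)[O-])c1)C(C)C` in this assay gives > 60000 nM, also a limit. Compound 1 therefore holds no distinct place among the shown numbers: the limit of > 60000 nM in this assay, at which 3 of the 3 values shown sit, so no compound can be ranked against another. Among the measured compounds shown here, no pair among them differs in one place, so no measured step is available.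

Compound 4 `CN(CC(=O)N1CCc2ccccc2C1)C(=O)c1ccc(S(C)(=O)=O)c([N+](=O)[O-])c1` differs from compound 1 by 1,2,3,4-tetrahydroisoquinolin-2-yl in place of 4-methylpiperidin-1-yl on a carbonyl carbon. The three measured compounds carry different amide groups and all sit at the limit. The step that the limit leaves unreadable from compound 1 to compound 4 is therefore expected to be none beyond the scatter, with compound 4 most likely reported as a limit as well. For compound 4 the estimate in this assay is 100000 nM, with a range from 30000 nM to 300000 nM.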

Compound 4, half-maximal inhibitory concentration: > 60000 nM
Compound 4: no number, only a limit (the forecaster's own chance of this, stated with the estimate: 85%); the middle value does not contradict the limit.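

No step can be read from compound 1 to compound 4, because both stand at a limit and not at a number: the limit of > 60000 nM in this assay, at which 4 of the 4 values shown sit.

The compounds shown leave open whether any amide group on the shared core gives a readable value, and how 1,2,3,4-tetrahydroisoquinolin-2-yl compares with 4-methylpiperidin-1-yl.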